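The source may report more compounds than this note shows. Statements on the series, on what has been measured and on what is new or still open speak of the compounds shown alone.

Going by the values given here, compound 2 `O=C(Nc1ccc(Cl)c(-c2nnc3c(Cl)cccn23)c1)c1ccc(Cl)cc1` is the only member of this set with a number in a functional assay on A549 cells (Homo sapiens) for antiproliferative activity, read by MTT assay, with a stated time of 72 h (a higher number here means a weaker inhibitor, a lower number a stronger inhibitor), where compound 2 gives 73600 nM. Compound 1 `O=C(Nc1ccc(Cl)c(-c2nnc3c(Cl)cccn23)c1)c1ccccn1` reaches only a limit in this assay, > 100000 nM. Among the compounds with values here, the single measured step, an at least 1.3-fold lower number from compound 1 to compound 2 (0.13 log units; that floor lies within the scatter), therefore rests on that limit of > 100000 nM in this assay, at which 1 of the 2 values shown sits, and carries a floor that lies within the scatter. Compound 3 `O=C(Nc1ccc(Cl)c(-c2nnc3c(Cl)cccn23)c1)c1cccc(Cl)c1` differs from compound 2 by 3-chlorophenyl in place of 4-chlorophenyl on a carbonyl carbon. Within the data shown here, no measured step alters where a chlorine sits on an otherwise unchanged ring; the step from compound 1 to compound 2 exchanges one ring for another and offers no direct guide to this move. With the same atoms joined differently and the chlorophenyl ring retained, the expected step of a 1.1-fold lower number from compound 2 to compound 3 (0.02 log units; within the scatter) is none beyond the scatter. Compound 3 is thus estimated at 70000 nM, with a range from 25000 nM to 200000 nM in this assay.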

Compound 3, half-maximal inhibitory concentration: 52700 nM
The estimate for compound 3 lay 1.3-fold (0.12 log units) above the measured number; low and high end bracket the measured number.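

In this assay, going by these compounds alone, moving the chlorine gives a 1.4-fold lower number from compound 2 to compound 3 (0.15 log units; within the scatter), so for the first time the chlorophenyl ring is varied on its own, and compound 2 and compound 3 cannot be told apart at this place on the carbonyl carbon. Exchanging the pyridin-2-yl group for the 3-chlorophenyl group gives an at least 1.8-fold lower number from compound 1 to compound 3 (0.27 log units; that floor lies within the scatter), so this second chlorophenyl comparison also fails to clear the scatter. Compound 1 stands at a limit, which makes both of its steps floors and not sizes: the limit of > 100000 nM in this assay, at which 1 of the 3 values shown sits.

From the compounds shown here alone, whether a methoxy group, an amine or a carboxylic acid in place of the chlorine on this phenyl ring would give a number beyond the scatter stays open. Going by these compounds, the shared core is the same in all three compounds, so what its own chlorines contribute also stays open.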